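The compounds below may be only part of what the source reports. "The series", "measured", "known", "first", "only" and "open" are said of these compounds alone.

Measured compounds:
- compound 1, `COc1cc(C(=O)c2sc(-c3ccc(Cl)cc3)cc2N)cc(OC)c1OC`: 70 nM
- compound 2, `COc1cc(C(=O)c2sc(-c3cc(OC)c(OC)c(OC)c3)cc2N)cc(OC)c1OC`: 840 nM
- compound 3, `COc1cc(C(=O)c2sc(-c3ccsc3)cc2N)cc(OC)c1OC`: 9.6 nM

In a functional assay on CCRF-CEM cells (Homo sapiens) for antiproliferative activity (a lower number here means a stronger inhibitor, a higher number a weaker inhibitor), compound 3 gives the lowest number of the three; compound 1 is nearest, and compound 2 lies furthest away. Going by the values given here, the one direct comparison is a 7.3-fold lower number from compound 1 to compound 3 (0.86 log units; beyond the scatter), where a six-membered ring of carbon only gave way to a five-membered aromatic ring with one hetero atom at the same place, next to the ring sulfur.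

Compound 4, `COc1ccc(-c2cc(N)c(C(=O)c3cc(OC)c(OC)c(OC)c3)s2)cc1OC`, takes the opposite route: 3,4-dimethoxyphenyl in place of thiophen-3-yl on an aromatic carbon. The change reverses the kind of swap seen between compound 1 and compound 3, and the group entering carries two methoxy groups, which puts it between the 4-chlorophenyl of compound 1 and the 3,4,5-trimethoxyphenyl of compound 2 in that respect. Both of those six-membered rings gave clearly higher numbers than compound 3 in this assay, so a rise beyond the scatter is expected for compound 4, on the order of a 26-fold higher number from compound 3 to compound 4 (1.42 log units; beyond the scatter). Compound 4 is estimated at 250 nM, with a likely range from 60 nM to 1000 nM.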

Compound 4, half-maximal inhibitory concentration: 20 nM
Beside the measured number, compound 4's estimate is 13-fold (1.10 log units) above it; the measured number lies below the stated range.
By their numbers in this assay, from the lowest: compound 3; then compound 4; then compound 1; then compound 2.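

At this position, on an aromatic carbon next to the ring sulfur, a six-membered ring of carbon only can come close to the thiophen-3-yl of compound 3, though a 2.1-fold higher number from compound 3 to compound 4 (0.32 log units; beyond the scatter) in this assay is still beyond the scatter. The six-membered rings also differ widely among themselves: a 3.5-fold lower number from compound 1 to compound 4 (0.54 log units; beyond the scatter) favours 3,4-dimethoxyphenyl over 4-chlorophenyl, and a 42-fold lower number from compound 2 to compound 4 (1.62 log units; beyond the scatter) is the largest step here, so hydrogen in place of a single methoxy on that ring matters far more than the change of ring type. Nothing available explains these differences.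

The compounds shown leave open how an unsubstituted phenyl or a phenyl with one methoxy group would compare. They also leave open whether an amine or a carboxylic acid on this ring would be tolerated.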